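The source may hold more compounds than are shown below. What is called first, only, known or untested is meant among the compounds shown, and "the series" means these compounds.

Compound 3 `CN(C[C@H]1Cc2c(cccc2N2CCN3CCC[C@H]3C2)CN1)[C@H]1CCCc2cccnc21` gives 2.92 nM in a functional assay on CCRF-CEM cells for antagonist activity at C-X-C chemokine receptor type 4 (Homo sapiens), read by calcium flux, with stated times of 25 min and 90 s (on this read-out lower numbers stand for stronger inhibition and higher numbers for weaker inhibition), the lowest of the three numbers in hand. Compound 1 `C[C@@H]1CN(c2cccc3c2C[C@H](CN(C)[C@H]2CCCc4cccnc42)NC3)C[C@H](C)N1` gives 61 nM and compound 2 `CN(C[C@H]1Cc2c(cccc2N2CCNC(C)(C)C2)CN1)[C@H]1CCCc2cccnc21` gives 33.9 nM; the steps of a 21-fold lower number from compound 1 to compound 3 (1.32 log units; beyond the scatter) and a 12-fold lower number from compound 2 to compound 3 (1.06 log units; beyond the scatter) are both large, whereas a 1.8-fold lower number from compound 1 to compound 2 (0.26 log units; within the scatter) is not. Compound 4 `C[C@@H]1CN(c2cccc3c2C[C@H](CN(C)[C@H]2CCCc4cccnc42)NC3)C[C@H](C)N1C` differs from compound 3 by a group of 9 heavy atoms (7 carbon, 2 nitrogen; one six-membered non-aromatic ring with 2 hetero atoms) in place of a group of 9 heavy atoms (7 carbon, 2 nitrogen; one five-membered non-aromatic ring with 1 hetero atom, one six-membered non-aromatic ring with 2 hetero atoms), on an aromatic carbon. This reverses the kind of change that produced the large steps to compound 3: a group with one six-membered non-aromatic ring with two hetero atoms, here 3,4,5-trimethylpiperazin-1-yl, again replaces the group with a five-membered and a six-membered ring on the aromatic carbon. Going by these compounds, those two steps therefore bear on it, and a move back toward the numbers of compound 1 and compound 2 is expected, though the effect of the added methyl is untested. Compound 4 is expected to give 40 nM, range 12 nM to 130 nM, an estimated step of a 14-fold higher number from compound 3 to compound 4 (1.14 log units; beyond the scatter) in this assay.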

Compound 4, half-maximal inhibitory concentration: 14.1 nM
The estimate for compound 4 lay 2.8-fold (0.45 log units) above the measured number; the range from low to high includes it.
By their numbers in this assay, from the lowest: compound 3; then compound 4; then compounds 2 and 1 (each within the scatter of the next).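

In this assay, among these compounds, methyl in place of hydrogen on the amine nitrogen in a ring gives a 4.3-fold lower number from compound 1 to compound 4 (0.64 log units; beyond the scatter), the first evidence in this set that substitution on that nitrogen moves the number. The 3,4,5-trimethylpiperazin-1-yl group also improves on 3,3-dimethylpiperazin-1-yl, with a 2.4-fold lower number from compound 2 to compound 4 (0.38 log units; beyond the scatter), but does not match the two-ring group, with a 4.8-fold higher number from compound 3 to compound 4 (0.68 log units; beyond the scatter). Nothing at hand explains these differences. Going by these compounds, whether an ethyl or 2-hydroxyethyl group on that ring nitrogen would narrow the remaining gap to compound 3 stays open.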